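Swapping the Aryl Group on a Hydrazone Urea

This account rests on a few compounds, and the source may have more. Where it says the series, first, only, none or still open, it means among the compounds named here.

Among the compounds with values here, compound 1 `CN(C)CCn1cnnc1-c1cc(Oc2ccc(NC(=O)N/N=C/c3ccc(Cl)cc3Cl)cc2F)ccn1` is tested in a functional assay on HT-29 cells (Homo sapiens) for cytotoxicity, read by MTT assay, with a stated time of 72 h (a higher number here means a weaker inhibitor, a lower number a stronger inhibitor), and gives 390 nM, the lowest of the two numbers measured so far. Its closest neighbour, compound 2 `CN(C)CCn1cnnc1-c1cc(Oc2ccc(NC(=O)N/N=C/c3ccccc3O[N+](=O)[O-])cc2F)ccn1`, gives 950 nM in this assay, so that the change a 2.4-fold higher number from compound 1 to compound 2 (0.39 log units; beyond the scatter) is a modest loss of potency. The unmeasured compound 3 `CN(C)CCn1cnnc1-c1cc(Oc2ccc(NC(=O)N/N=C/c3ccc(F)cc3)cc2F)ccn1` differs from compound 1 in one place: 4-fluorophenyl in place of 2,4-dichlorophenyl on a carbon with a double bond to nitrogen. Within the data shown here, the only step that bears on this change is the one from compound 1 to compound 2, where a different aryl group at the same position also gave a weaker compound, and it is modest in size. A step of similar kind, in the same direction, is therefore expected in this assay: compound 3 is expected to show a modestly higher number than compound 1, a 1.8-fold higher number from compound 1 to compound 3 (0.25 log units; within the scatter). The estimate for compound 3 is 700 nM, with a range from 300 nM to 1800 nM.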

Compound 3, half-maximal inhibitory concentration: 1370 nM
The estimate for compound 3 lay 2.0-fold (0.29 log units) below the measured number, within the range that was stated.
By their numbers in this assay, from the lowest: compound 1; then compounds 2 and 3 (each within the scatter of the next).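

In this assay, both replacements of 2,4-dichlorophenyl on the carbon with a double bond to nitrogen now give weaker compounds: 4-fluorophenyl gives a clear loss (a 3.5-fold higher number from compound 1 to compound 3 (0.55 log units; beyond the scatter)), as 2-(nitrooxy)phenyl did before it. The two replacements themselves cannot be told apart (a 1.4-fold higher number from compound 2 to compound 3 (0.16 log units; within the scatter)), so in this small set, compound 1 stands alone and the choice between these two entering groups makes no visible difference. Nothing available explains why the 2,4-dichlorophenyl compound keeps the lowest number.

From the compounds shown here alone, all three compounds carry a six-membered aromatic ring of carbon only at this place, so it remains open whether a single chlorine, as in 4-chlorophenyl, would be enough to keep the number of compound 1. Also open, going by these compounds, is how a ring without aromatic character, such as cyclohexyl, or a phenyl ring carrying an amine would fare here.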